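The compounds below may be only part of what the source reports. "The series", "measured", "known", "first", "only" and "open" are said of these compounds alone.

Measured so far:
compound 1 `Cc1ccc(-n2cc(COc3ccc4c(c3)CCC4)nn2)c(C)c1` — 19.9%
compound 2 `Brc1ccccc1-n1cc(COc2ccc3c(c2)CCC3)nn1` — 16.5%

In an ADME assay on HEK293 cells (Homo sapiens) for inhibition, read by MTT assay, with a stated time of 48 h, tested at 25 uM (a lower number here means less inhibition, a higher number more inhibition at the concentration tested (going by the name of the read-out)), compound 1 gives 19.9% and compound 2 gives 16.5%. Compound 2 holds the lowest of the two numbers; its nearest neighbour is compound 1, and the step of a number 3.4 percentage points lower from compound 1 to compound 2 (within the scatter) lies within the scatter, so the two cannot be ordered.

Compound 3 `Fc1ccccc1-n1cc(COc2ccc3c(c2)CCC3)nn1` is the next point. The change from compound 2 to compound 3 is fluoro in place of bromo on an aromatic carbon.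

Among the compounds with values here, no measured step exchanges one halogen for another, so nothing in the two numbers bears directly on this change. Within the data shown here, the only measured step, a number 3.4 percentage points lower from compound 1 to compound 2 (within the scatter), replaced the whole aryl group on the aromatic nitrogen and still stayed within the scatter, which gives no sign that this part of the molecule moves the read-out. The step of a number 0.5 percentage points higher from compound 2 to compound 3 (within the scatter) is therefore expected to stay within the scatter, with no direction. Compound 3 is estimated at 17%, within 8% to 28%.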

Compound 3, a percentage reported as inhibition, at one concentration (the size of the read-out at that concentration, not a potency): 21%
The estimate for compound 3 lay 4 percentage points below the measured number; measured number inside the range.
By their numbers in this assay, from the lowest: compounds 2, 1 and 3 (each within the scatter of the next).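

Within the data shown here, the step of a number 4.5 percentage points higher from compound 2 to compound 3 (within the scatter) in this assay is the first direct exchange of one halogen for another on this aromatic carbon, ortho to a large group, and it gives no basis for ordering 2-fluorophenyl and 2-bromophenyl. The step of a number 1.1 percentage points higher from compound 1 to compound 3 (within the scatter) likewise gives no basis for ordering 2-fluorophenyl and 2,4-dimethylphenyl on the aromatic nitrogen, so all three aryl groups shown now read alike in this assay. There is no supporting information that could account for these numbers.

The compounds shown leave open whether a group of another kind on this aryl ring, such as an amine or a carboxylic acid, would give a step beyond the scatter. They also leave open whether any change to the shared core would do so.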